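This account rests on a few compounds, and the source may have more. Where it says the series, first, only, none or still open, it means among the compounds named here.

In an ADME assay on L6 cells (Rattus norvegicus) for cytotoxicity, read by resazurin assay, with a stated time of 70 h (on this read-out higher numbers stand for weaker inhibition and lower numbers for stronger inhibition), three compounds of a shared core have been measured. Compound 1 `COc1cc(NC(C)CCCNC(=O)NNC(=O)/C(C)=C/c2ccccc2)c2ncccc2c1` gives 36500 nM, compound 2 `COc1cc(NC(C)CCCNC(=O)NNC(=O)/C=C/c2ccc(OC)c(OC)c2)c2ncccc2c1` gives 37000 nM, and compound 3 `COc1cc(NC(C)CCCNC(=O)NNC(=O)/C=C/c2cccc(C(F)(F)F)c2)c2ncccc2c1` gives 10600 nM. Compound 3 holds the lowest of the three numbers: the step was a 3.4-fold lower number from compound 1 to compound 3 (0.54 log units; beyond the scatter) and a 3.5-fold lower number from compound 2 to compound 3 (0.54 log units; beyond the scatter), while a 1.0-fold higher number from compound 1 to compound 2 (0.01 log units; within the scatter). Compound 4 `COc1cc(NC(C)CCCNC(=O)NNC(=O)/C=C/c2cc(C(F)(F)F)cc(C(F)(F)F)c2)c2ncccc2c1` differs from compound 3 by trifluoromethyl in place of hydrogen on an aromatic carbon. Within the data shown here, no measured step adds a trifluoromethyl group to a ring that already carries one; the nearest guide is the exchange of the dimethoxyphenyl for the trifluoromethylphenyl, which gave a 3.5-fold lower number from compound 2 to compound 3 (0.54 log units; beyond the scatter), a modest move downward. A further trifluoromethyl on the same ring is therefore expected to move the number of compound 4 in this assay only a little, if at all, with the direction leaning downward; the estimated step is a 1.5-fold lower number from compound 3 to compound 4 (0.18 log units; within the scatter). Compound 4 is accordingly expected to give about 7000 nM in this assay, with a range from 3000 nM to 18000 nM.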

Compound 4, half-maximal inhibitory concentration: > 170000 nM
Compound 4: no number, only a limit; the forecaster's own chance of this, stated with the estimate: 5%; middle value at least 24-fold (1.38 log units) from the limit.
By their numbers in this assay, from the lowest: compound 3; then compounds 1 and 2 (each within the scatter of the next). At a limit, above all of these: compound 4.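

In this assay, adding a second trifluoromethyl to the aromatic ring, at a place meta to a trifluoromethyl group, moves the number upward rather than further down: an at least 16-fold higher number from compound 3 to compound 4 (1.20 log units; beyond the scatter). Going by these compounds, compound 4 has only a limit and not a number, so the full size of this step remains unknown: the limit of > 170000 nM in this assay, at which 1 of the 4 values shown sits. The earlier steps shown here between compounds were at most modest, so this single change at one ring position shows a much larger shift than any of them did.

The compounds shown leave open whether this rise belongs to trifluoromethyl itself or would also follow from another second group at this place, such as a chlorine atom or an amine. They also leave open whether moving the second trifluoromethyl to another ring position would give a similar shift.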